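The compounds below may be only part of what the source reports. "The series", "measured", "known", "first", "only" and "open" are said of these compounds alone.

Compound 1 `CC1(c2ccc(-c3cccc(/C(N)=N\O)c3)cc2)CC(S(=O)(=O)c2ccc(F)cc2)=C(c2ccc(/C(N)=N\O)cc2)O1`: 19000 nM
Compound 2 `CC1(c2ccc(-c3ccncc3)cc2)CC(S(=O)(=O)c2ccc(F)cc2)=C(c2ccc(/C(N)=N\O)cc2)O1`: 30300 nM

In an ADME assay on HepG2 cells (Homo sapiens) for cytotoxicity, read by MTT assay, with a stated time of 72 h (on this read-out lower numbers stand for higher toxicity in this test and higher numbers for lower toxicity in this test), compound 2 stands highest of the two numbers shown, with compound 1 as its nearest neighbour, and the step of a 1.6-fold higher number from compound 1 to compound 2 (0.20 log units; within the scatter) lies within the scatter. Compound 3 `COc1cc(-c2ccc(C3(C)CC(S(=O)(=O)c4ccc(F)cc4)=C(c4ccc(/C(N)=N\O)cc4)O3)cc2)cc(OC)c1OC` carries the change (3,4,5-trimethoxyphenyl in place of pyridin-4-yl on an aromatic carbon). Within the data shown here, the only measured step that bears on this place is the one from compound 1 to compound 2, which changed the same aromatic group and stayed within the scatter. Compound 3 is therefore expected to sit close to compound 2, with a 1.2-fold lower number from compound 2 to compound 3 (0.08 log units; within the scatter) not beyond the scatter. The estimate for compound 3 in this assay is 25000 nM, with a range from 10000 nM to 60000 nM.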

Compound 3, half-maximal cytotoxic concentration: > 50000 nM
Compound 3: no number, only a limit; the forecaster's own chance of this, stated with the estimate: 10%; middle value at least 2.0-fold (0.30 log units) from the limit.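

Compound 3 gives no number in this assay, only a limit: the limit of > 50000 nM in this assay, at which 1 of the 3 values shown sits.

Replacing pyridin-4-yl with 3,4,5-trimethoxyphenyl gives an at least 1.6-fold higher number from compound 2 to compound 3 (0.21 log units; that floor lies within the scatter), so this change is not yet separated from pyridin-4-yl. Among these compounds, at this place on the aromatic ring, the compounds now show a first step beyond the scatter, an at least 2.6-fold higher number from compound 1 to compound 3 (0.42 log units; beyond the scatter).

On these data alone, how far compound 3 lies past its limit remains open. Also open, as far as these compounds go, is how an amine or a carboxylic acid at this place would read in this assay.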